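Lengthening the hydroxy chain of compound 3

A few compounds are considered here, and "the series" means these few. Any claim that something is new, unique, unknown or untested is made for them only; others in the source may bear on it.

Compound 3 `Cc1ccsc1C(=CCCN(C)C(CO)C(=O)NCc1ccc(F)cc1)c1sccc1C` is the starting point here. Among the compounds with values here, in a physicochemical assay for lipophilicity, read by HPLC (on this read-out lower numbers stand for lower lipophilicity and higher numbers for higher lipophilicity), compound 3 gives 6.45, the only number available for it, while two further entries came without a single number.

Compound 4 `Cc1ccsc1C(=CCCN(C)C(CC(C)O)C(=O)NCc1ccc(F)cc1)c1sccc1C` differs from it in one place: 1-hydroxyethyl in place of hydroxy on a saturated chain carbon, two bonds along the chain from an amine nitrogen and a carbonyl carbon. In words, 1-hydroxyethyl stands in place of hydroxy on a saturated chain carbon, two bonds along the chain from an amine nitrogen and a carbonyl carbon. The same difference can be read as hydroxymethyl becoming 2-hydroxypropyl.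

Within the data shown here, no measured pair shows this change on its own. The nearest guides are two compounds that already carry the 2-hydroxypropyl chain, with chlorine where compound 4 has fluorine. Compound 2 `Cc1ccsc1C(=CCCN(C)C(CC(C)O)C(=O)NCc1ccccc1Cl)c1sccc1C` gives 5.95; 5.67 (2 entries) in this assay. Compound 1 `Cc1ccsc1C(=CCCN(C)C(CC(C)O)C(=O)NCc1ccc(Cl)cc1)c1sccc1C` gives 5.99; 6.77 (2 entries), entries that lie far apart and fall on either side of the number for compound 3, so no shift beyond the usual scatter is expected. The estimated change is a number 0.05 log units lower from compound 3 to compound 4 (within the scatter). For compound 4 the expected value is 6.4, with an estimated range of 5.8 to 7.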

Compound 4, partition coefficient: 5.51
For compound 4 the middle estimate is 0.89 log units above the measured one, and the stated range ends above it.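

Within the data shown here, this is the first measured one-place step at this saturated chain carbon: in this assay hydroxymethyl becoming 2-hydroxypropyl gives a number 0.94 log units lower from compound 3 to compound 4 (beyond the scatter). The direction is the new information, as the entering 1-hydroxyethyl brings in 2 carbon atoms, yet the number fell, while the leaving and entering groups each count 1 hydrogen-bond donor, 1 hydrogen-bond acceptor and no net charge. Compound 1 and compound 2 carry only the 2-hydroxypropyl chain, and neither offers such a step on its own.

This single step does not separate the length of the chain from the place of the hydroxy group on it, and 2-hydroxyethyl, a longer chain or an amine in place of the hydroxy would each probe a different part of the change. It also remains unclear whether fluorine and chlorine give the same level on this chain, as the entries of compound 1 lie far apart: the several entries of compound 1 in this assay, 5.99; 6.77 (2 entries).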